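Compound 3 to compound 4: fluoro in place of methyl

This account rests on a few compounds, and the source may have more. Where it says the series, first, only, none or still open, it means among the compounds named here.

In a functional assay on MCF7 cells (Homo sapiens) for antiproliferative activity, read by sulforhodamine B assay, with a stated time of 48 h (a higher number here means a weaker inhibitor, a lower number a stronger inhibitor), compound 3 `Cc1ccc(NS(=O)(=O)c2ccc(N3CCNC3=O)cc2)cc1` gives 610 nM and compound 1 `CCc1ccccc1NS(=O)(=O)c1ccc(N2CCNC2=O)cc1` gives 350 nM, so the two cannot be ranked. Compound 2 `O=C1NCCN1c1ccc(S(=O)(=O)Nc2ccc(C3CCCCC3)cc2)cc1` gives > 1000 nM, which is a limit and not a number. Compound 3 therefore has one numerical neighbour in the series.

The next change leads to compound 4 `O=C1NCCN1c1ccc(S(=O)(=O)Nc2ccc(F)cc2)cc1`, with fluoro in place of methyl on an aromatic carbon, para to a large group: fluoro in place of methyl on an aromatic carbon.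

Among the compounds with values here, no measured step makes this exact replacement, but two bear on it. Methyl in place of cyclohexyl on an aromatic carbon gives an at least 1.6-fold lower number from compound 2 to compound 3 (0.21 log units; that floor lies within the scatter). This also changes a group on an aromatic carbon, but it offers only a floor. A change of the group on the sulfonamide nitrogen gives a 1.7-fold higher number from compound 1 to compound 3 (0.24 log units; within the scatter). Neither result supports a large step for a smaller replacement, so no step beyond the scatter is expected in this assay, and no direction can be assigned with confidence.

The expected step is a 1.1-fold higher number from compound 3 to compound 4 (0.06 log units; within the scatter). For compound 4 the estimated value is 700 nM, with an expected range of 280 nM to 1800 nM.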

Compound 4, half-maximal inhibitory concentration: 690 nM
For compound 4 the middle estimate is 1.0-fold (0.01 log units) above the measured one; low and high end bracket the measured number.
By their numbers in this assay, from the lowest: compounds 1, 3 and 4 (each within the scatter of the next). At a limit, above all of these: compound 2.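

In this assay, 4-fluorophenyl in place of 4-methylphenyl gives a 1.1-fold higher number from compound 3 to compound 4 (0.05 log units; within the scatter), so this exchange of one heavy atom on an aromatic carbon, para to a large group, shows no change that can be told from the scatter. Fluoro in place of cyclohexyl at the same place gives an at least 1.4-fold lower number from compound 2 to compound 4 (0.16 log units; that floor lies within the scatter), and the reading for compound 2 is a limit and not a number: the limit of > 1000 nM in this assay, at which 1 of the 4 values shown sits. On the sulfonamide nitrogen, 4-fluorophenyl in place of 2-ethylphenyl gives a 2.0-fold higher number from compound 1 to compound 4 (0.29 log units; within the scatter), so the series now holds three numerical values with no order among them.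

With cyclohexyl read only as a limit, the compounds shown give no step beyond the scatter at this place, and how far the number can move there remains unknown. As far as these compounds go, whether an amine, a carboxylic acid, a methoxy group or a tert-butyl group at this place would give such a step stays open.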